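Notes on the carbonyl aryl change, compound 2 to compound 3

The source may report more compounds than this note shows. Statements on the series, on what has been measured and on what is new or still open speak of the compounds shown alone.

Compound 2 `Cc1cncc(C(=O)n2c(-c3cn(-c4ccccc4)nc3-c3ccc(C(F)(F)F)cc3)nc3ccccc32)c1` gives 123000 nM in an ADME assay on HEK-293T cells (Homo sapiens) for cytotoxicity, read by MTT assay, with a stated time of 24 h; on this read-out higher numbers stand for lower toxicity in this test and lower numbers for higher toxicity in this test. Compound 1 `Cc1ccc(-c2nn(-c3ccccc3)cc2-c2nc3ccccc3n2C(=O)c2cncc(C)c2)cc1` gives 155000 nM in this assay. For the measured compounds named here, compound 2 holds the lowest of the two numbers, its nearest neighbour being compound 1, but a 1.3-fold lower number from compound 1 to compound 2 (0.10 log units; within the scatter) is the only measured step in the set and lies within the scatter, so no order between the two can be drawn. Compound 3 `Cc1ccc(C(=O)n2c(-c3cn(-c4ccccc4)nc3-c3ccc(C(F)(F)F)cc3)nc3ccccc32)cn1` differs from compound 2 in one place: 6-methylpyridin-3-yl in place of 5-methylpyridin-3-yl on a carbonyl carbon. The measured step concerns another part of the molecule, trifluoromethyl in place of methyl on an aromatic carbon, and does not bear on this change. Nothing in the data points either way. Compound 3 is therefore expected to sit close to compound 2, the expected step being a 1.0-fold lower number from compound 2 to compound 3 (0.01 log units; within the scatter), none beyond the scatter. Compound 3 is estimated at 120000 nM, with a range from 55000 nM to 260000 nM.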

Compound 3, half-maximal cytotoxic concentration: 153000 nM
The estimate for compound 3 lay 1.3-fold (0.11 log units) below the measured number; measured number inside the range.
By their numbers in this assay, from the lowest: compounds 2, 3 and 1 (each within the scatter of the next).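

In this assay, for the compounds shown here, the exchange of 5-methylpyridin-3-yl for 6-methylpyridin-3-yl on the carbonyl carbon gives a 1.2-fold higher number from compound 2 to compound 3 (0.09 log units; within the scatter) and is the first reading at this position. The two isomers, with the same atoms joined differently, cannot be told apart on this read-out, so the place of the methyl on the pyridine ring has no measurable bearing here. This holds only for this pair, and no further measurement helps to interpret it.

Open, going by these compounds, is whether a larger change on the carbonyl carbon, such as a plain phenyl ring or a pyridine carrying an amine or a carboxylic acid in place of the methyl, would give a step beyond the scatter. Also open, on these data alone, is whether 6-methylpyridin-3-yl reads the same when methyl replaces trifluoromethyl on the aromatic carbon.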